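This account rests on a few compounds, and the source may have more. Where it says the series, first, only, none or still open, it means among the compounds named here.

Measured so far:
Compound 1 `CCc1nc(C(F)(F)F)c2n1CCN([C@@H](C(=O)NC)c1ccccc1)[C@H]2CCc1ccc(C(F)(F)F)cc1` — in a functional assay on CHO cells for antagonist activity at Orexin/Hypocretin receptor type 1 (Homo sapiens), read by FLIPR and calcium flux (a higher number here means a weaker inhibitor, a lower number a stronger inhibitor), compound 1 gives 1070 nM.
Compound 2 `C=Cc1nc(CC)n2c1C(CCc1ccc(C(F)(F)F)cc1)N([C@@H](C(=O)NC)c1ccccc1)CC2` — in this assay compound 2 gives 150 nM.
Compound 3 `CNC(=O)[C@@H](c1ccccc1)N1CCn2c(C(C)C)nc(Cl)c2[C@@H]1CCc1ccc(C(F)(F)F)cc1` — in this assay compound 3 gives 313 nM.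

Compound 2 carries the lowest number of the three; compound 3 stands nearest to it, already beyond the scatter, and compound 1 furthest. Compound 4 `CCc1ncc2n1CCN([C@@H](C(=O)NC)c1ccccc1)C2CCc1ccc(C(F)(F)F)cc1` is not yet measured. Relative to compound 2 the change is hydrogen in place of vinyl on an aromatic carbon. Among the measured compounds shown here, no single-change pair among the measured compounds covers this position: compounds 1 and 3 carry other groups there together with other alkyl groups, so their values do not isolate the effect. In this assay the expected step is a 3.0-fold higher number from compound 2 to compound 4 (0.48 log units; beyond the scatter), a weakening likely beyond the scatter. For compound 4 the estimate is 450 nM, with a range of 150 nM to 1300 nM.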

Compound 4, half-maximal inhibitory concentration: 10000 nM
The estimate for compound 4 lay 22-fold (1.35 log units) below the measured number, and the stated range ends below it.
By their numbers in this assay, from the lowest: compound 2; then compound 3; then compound 1; then compound 4.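

In this assay hydrogen in place of vinyl on this aromatic carbon gives a 67-fold higher number from compound 2 to compound 4 (1.82 log units; beyond the scatter) as a large step, the first to isolate this position. The series therefore depends strongly on carrying a substituent here, and the unsubstituted aromatic carbon does not hold the level of compound 2. Nothing available accounts for the loss.

Going by these compounds, whether methyl at this position would recover part of the step remains open. Ethyl here would show whether the double bond of vinyl matters or only its two carbons.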